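The source may hold more compounds than are shown below. What is called first, only, known or untested is meant among the compounds shown, and "the series" means these compounds.

Measured compounds:
Compound 1 `COc1ccc(-c2cc3cc(-c4ccccc4)cc(C(C)=O)c3[nH]2)cc1`: 51.6%
Compound 2 `COc1ccc(-c2cc(C(C)=O)c3[nH]c(-c4ccc(OC)cc4)cc3c2)cc1`: 37.1%

In a functional assay on HeLa cells (Homo sapiens) for cytotoxicity, read by MTT assay, with a stated time of 2 days, tested at 10 uM (on this read-out higher numbers stand for a weaker effect at the one concentration tested and lower numbers for a stronger effect), compound 1 gives 51.6%, while compound 2 gives 37.1%. Compound 2 therefore stands lowest of the two numbers; its nearest neighbour is compound 1, and the step of a number 14.5 percentage points lower from compound 1 to compound 2 (beyond the scatter) accompanies a methoxy in place of hydrogen on an aromatic carbon.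

Compound 3 `COc1ccc(-c2cc3cc(/C=C/c4ccc(F)cc4)cc(C(C)=O)c3[nH]2)cc1` has not yet been measured. It differs from compound 2 by 2-(4-fluorophenyl)ethenyl in place of 4-methoxyphenyl on an aromatic carbon. Going by the values given here, no measured step bears directly on this exchange: the only step known, a number 14.5 percentage points lower from compound 1 to compound 2 (beyond the scatter), concerns a methoxy added to a ring, whereas here a whole 4-methoxyphenyl group gives way to a 2-(4-fluorophenyl)ethenyl group, a change of a different kind. Among the compounds with values here, the one step shows that a single alteration on this shared core shifts the read-out modestly rather than dramatically. For compound 3 the step from compound 2 is expected to be a number 4.9 percentage points higher from compound 2 to compound 3 (within the scatter), in no clear direction and possibly within the scatter. The estimate for compound 3 is therefore 42%, with a range from 22% to 65%.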

Compound 3, a percentage reported as activity, at one concentration (the size of the read-out at that concentration, not a potency): 25.8%
For compound 3 the middle estimate is 16.2 percentage points above the measured one; measured number inside the range.
By their numbers in this assay, from the lowest: compound 3; then compound 2; then compound 1.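

In this assay, the position meta to an acetyl group tolerates more than a ring attached directly to the shared core: exchanging 4-methoxyphenyl for 2-(4-fluorophenyl)ethenyl gives a number 11.3 percentage points lower from compound 2 to compound 3 (beyond the scatter), and exchanging phenyl for the same group gives a number 25.8 percentage points lower from compound 1 to compound 3 (beyond the scatter). Going by these compounds alone, until now, the only change seen was a methoxy added to the ring at this position, whereas these two steps replace the whole group, and both point towards a stronger effect at the one concentration tested. Nothing available explains why this group lowers the number.

The new group differs from the earlier ones in two ways at once, a double bond and a fluorine, so the compounds shown cannot say which of the two goes with the lower number; a plain 2-phenylethenyl group or a directly attached 4-fluorophenyl group would separate them. Also open, going by these compounds, is how this position responds to groups of a quite different kind, such as an amine or a carboxylic acid at the end of the chain.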